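From a Nine-Atom Group to 1-Carboxyethyl

The source may hold more compounds than are shown below. What is called first, only, known or untested is meant among the compounds shown, and "the series" means these compounds.

In a functional assay on HepG2 cells (Homo sapiens) for antiproliferative activity, read by MTT assay, with a stated time of 48 h (a higher number here means a weaker inhibitor, a lower number a stronger inhibitor), compound 1 `CCn1c(C(=O)NCCCN(C)C)ccc1C(CC)(CC)c1ccc(OCCC(O)(CC)CC)c(C)c1` gives 110 nM. Compound 2 `C#CCCOC(=O)c1ccc(C(CC)(CC)c2ccc(OCCC(O)(CC)CC)c(C)c2)n1CC` reaches only a limit, > 50000 nM. Compound 3 `CCn1c(C(=O)NC(CC(=O)O)C(=O)OC)ccc1C(CC)(CC)c1ccc(OCCC(O)(CC)CC)c(C)c1` gives 10700 nM, the higher of the two true numbers in the series. Compound 4 `CCn1c(C(=O)NC(C)C(=O)O)ccc1C(CC)(CC)c1ccc(OCCC(O)(CC)CC)c(C)c1` changes the group on the amide-type nitrogen of compound 3: a group of 5 heavy atoms (3 carbon, 2 oxygen; no ring) in place of a group of 9 heavy atoms (5 carbon, 4 oxygen; no ring), on an amide-type nitrogen. One measured step falls at this same place, a 97-fold higher number from compound 1 to compound 3 (1.99 log units; beyond the scatter), which is large and beyond the scatter. Two further steps, an at least 450-fold higher number from compound 1 to compound 2 (2.65 log units; beyond the scatter) and an at least 4.6-fold lower number from compound 2 to compound 3 (0.66 log units; beyond the scatter), fall on the carbonyl carbon and show how far the number can move in this series. Yet the group leaving compound 3 and the 1-carboxyethyl group entering compound 4 both have no ring and no net charge, so no repeat of the large step is expected. The expected change is small, a 1.4-fold higher number from compound 3 to compound 4 (0.15 log units; within the scatter), and does not clearly pass the scatter. For compound 4 the estimated value is 15000 nM, with an expected range of 4000 nM to 50000 nM.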

Compound 4, half-maximal inhibitory concentration: 1740 nM
Estimate against measurement, compound 4: 8.6-fold (0.94 log units) above; measured number outside the range, below it.
By their numbers in this assay, from the lowest: compound 1; then compound 4; then compound 3. At a limit, above all of these: compound 2.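

On the amide-type nitrogen, even two groups with no ring, no net charge and one hydrogen-bond donor each are not interchangeable: replacing the nine-atom group with 1-carboxyethyl gives a 6.1-fold lower number from compound 3 to compound 4 (0.79 log units; beyond the scatter). That recovery remains partial, since 3-(dimethylamino)propyl keeps the lowest number in the series, and the change to 1-carboxyethyl gives a 16-fold higher number from compound 1 to compound 4 (1.20 log units; beyond the scatter). On the carbonyl carbon, (1-carboxyethyl)amino in place of (but-3-yn-1-yl)oxy gives an at least 28-fold lower number from compound 2 to compound 4 (1.45 log units; beyond the scatter), and compound 2 is held only by a limit: the limit of > 50000 nM in this assay, at which 1 of the 4 values shown sits.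

The compounds shown leave open whether the smaller size of 1-carboxyethyl or some other difference from the nine-atom group accounts for the gain. From the compounds shown here alone, how a shorter chain ending in a dimethylamino group, or a methyl ester of 1-carboxyethyl, would compare also stays open.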